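The source may report more compounds than this note shows. Statements on the series, on what has been measured and on what is new or still open speak of the compounds shown alone.

Compound 1 `COc1cc(-c2cc(/C=C/C(=O)c3ccc(N)cc3)[nH]n2)cc(OC)c1OC`: 105%
Compound 2 `COc1ccc(-c2cc(/C=C/C(=O)c3ccc(OC)c(OC)c3)[nH]n2)cc1`: 77%

In a functional assay on OVCAR-4 cells (Homo sapiens) for cytotoxicity, read by sulforhodamine B assay, with a stated time of 48 h, tested at 0.1 uM (a higher number here means a weaker effect of the compound at the concentration tested, a lower number a stronger effect), compound 1 gives 105%, the higher of the two numbers; compound 2 gives 77%, a gap that lies beyond the usual scatter. Compound 3 `COc1cc(-c2cc(/C=C/C(=O)c3ccc(Cl)c(Cl)c3)[nH]n2)cc(OC)c1OC` has not yet been measured in this assay. It differs from compound 1 in one place: 3,4-dichlorophenyl in place of 4-aminophenyl on a carbonyl carbon. Among the compounds with values here, no measured pair shows this change, so its size is open. A modest decrease from compound 1 is expected, a number 15 percentage points lower from compound 1 to compound 3 (beyond the scatter), towards a stronger effect. Compound 3 is therefore estimated at 90%, within 65% to 108%.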

Compound 3, a percentage reported as activity, at one concentration (the size of the read-out at that concentration, not a potency): 106%
Beside the measured number, compound 3's estimate is 16 percentage points below it; the range from low to high includes it.
By their numbers in this assay, from the lowest: compound 2; then compounds 1 and 3 (each within the scatter of the next).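

In this assay, 3,4-dichlorophenyl in place of 4-aminophenyl on a carbonyl carbon gives a number 1 percentage points higher from compound 1 to compound 3 (within the scatter), so at this position the change brings no readable difference at the concentration tested. This holds even though the hydrogen-bond donor and acceptor counted on 4-aminophenyl are absent from 3,4-dichlorophenyl. No measured evidence is available to explain this result. As far as these compounds go, whether a carboxylic acid or a longer chain on the same carbonyl carbon would also leave the read-out within the scatter remains open. The compounds shown also leave open what other changes to the core of compound 1 would do.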